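Orexin type 2 antagonism: amide to urea on compound 2

This account rests on a few compounds, and the source may have more. Where it says the series, first, only, none or still open, it means among the compounds named here.

Measured in a functional assay on CHO cells for antagonist activity at Orexin receptor type 2 (Homo sapiens), read by FLIPR; a higher number here means a weaker inhibitor, a lower number a stronger inhibitor:
compound 1, `O=C(c1ccc(Cl)c(Cl)c1)N1CCCCC1CCOc1ccc(Cl)c(Cl)c1`, gives > 3160 nM; this is a limit of the assay, not a number.
compound 2, `O=C(NC[C@@H]1CCCCN1C(=O)c1ccccc1-c1ccccc1)c1ccccc1`, gives 20 nM.
compound 3, `CN(C[C@@H]1CCCCN1C(=O)c1ccccc1-c1ccccc1)C(=O)c1ccc(F)cc1`, gives 1260 nM.

Compound 2 carries the lowest of the two numbers; compound 3 stands well above it, beyond the scatter. Compound 1 sits at the limit of > 3160 nM in this assay, at which 1 of the 3 values shown sits.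

Compound 4, `O=C(NC[C@@H]1CCCCN1C(=O)c1ccccc1-c1ccccc1)Nc1ccccc1`, differs from compound 2 by anilino in place of phenyl on a carbonyl carbon. For the measured compounds named here, no measured pair in this set shows this change, so its size is open. The step from compound 2 to compound 4 is expected to be modest, toward a weaker inhibitor, at a 2.5-fold higher number from compound 2 to compound 4 (0.40 log units; beyond the scatter), possibly still within the scatter. Compound 4 is therefore estimated at 50 nM, with a range from 10 nM to 250 nM.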

Compound 4, inhibition constant: 5.01 nM
Beside the measured number, compound 4's estimate is 10-fold (1.00 log units) above it; the whole stated range lies above it.
By their numbers in this assay, from the lowest: compound 4; then compound 2; then compound 3. At a limit, above all of these: compound 1.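

In this assay, anilino in place of phenyl on a carbonyl carbon gives a 4.0-fold lower number from compound 2 to compound 4 (0.60 log units; beyond the scatter). For the compounds shown here, this is the first single-place change, and it shows that this carbonyl carbon accepts a group with one more hydrogen-bond donor while the inhibitor gets stronger. Nothing measured here accounts for the shift.

Open, from the compounds shown here alone, is how phenoxy or benzyl on the same carbonyl carbon would compare with anilino. Going by these compounds, a single pair carries this step, so its reach across the series also stays open.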